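Adding a triazole to the chain of compound 1

The source may report more compounds than this note shows. Statements on the series, on what has been measured and on what is new or still open speak of the compounds shown alone.

- compound 1 `COc1cc(/C=C/c2ccc(OCCCCC(=O)NO)cc2)cc(OC)c1` gives 3350 nM
- compound 2 `COc1cc(/C=C/c2ccc(OCc3ccc(C(=O)NO)cc3)cc2)cc(OC)c1` gives 10400 nM

Of these two numbers in a functional assay on HCT-116 cells (Homo sapiens) for cytotoxicity, read by MTT assay, with a stated time of 48 h (a lower number here means a stronger inhibitor, a higher number a weaker inhibitor), compound 1 holds the lowest, which makes it the stronger inhibitor of the pair. Compound 3 `COc1cc(/C=C/c2ccc(OCCc3cn(CC(=O)NO)nn3)cc2)cc(OC)c1` has not been measured yet. Its change from compound 1 is 1-((hydroxycarbamoyl)methyl)-1H-1,2,3-triazol-4-yl in place of 2-(hydroxycarbamoyl)ethyl on a saturated chain carbon, two bonds along the chain from an oxygen on an aromatic ring and it sits on a saturated chain carbon, two bonds along the chain from an oxygen on an aromatic ring. Going by the values given here, only one measured step bears on this: a 3.1-fold higher number from compound 1 to compound 2 (0.49 log units; beyond the scatter) with 4-(hydroxycarbamoyl)phenyl in place of 3-(hydroxycarbamoyl)propyl. That step also put an aromatic ring into the chain, and it was modest. A single step is thin evidence, but a modest rise is expected in this assay, meaning a somewhat weaker inhibitor. The expected step is a 1.8-fold higher number from compound 1 to compound 3 (0.25 log units; within the scatter) and carries wide uncertainty. The estimate for compound 3 is 6000 nM with 2000 nM to 18000 nM as its expected range.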

Compound 3, half-maximal inhibitory concentration: 7440 nM
For compound 3 the middle estimate is 1.2-fold (0.09 log units) below the measured one; measured number inside the range.
By their numbers in this assay, from the lowest: compound 1; then compounds 3 and 2 (each within the scatter of the next).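

Read in this assay the change to 1-((hydroxycarbamoyl)methyl)-1H-1,2,3-triazol-4-yl gives a 2.2-fold higher number from compound 1 to compound 3 (0.35 log units; beyond the scatter) and so shows that this place on the chain accepts a five-membered aromatic ring with 3 hetero atoms at only a modest cost. Together with the earlier step, this means that both ring-bearing chains shown, the phenyl one and the triazole one, give higher numbers than the open chain of compound 1, and no compound shown goes against this. Nothing given here explains the rise in compound 3.

On these data alone, it remains open whether a longer chain joining the triazole to the hydroxycarbamoyl group would bring the number closer to that of compound 1. Also open, as far as these compounds go, is how the triazole series would respond if a carboxylic acid took the place of the hydroxycarbamoyl group.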